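Chloro in place of methoxy: notes on the series

This account rests on a few compounds, and the source may have more. Where it says the series, first, only, none or still open, it means among the compounds named here.

In a functional assay on HUVEC cells (Homo sapiens) for inhibition, with a stated time of 4 days (a higher number here means a weaker inhibitor, a lower number a stronger inhibitor), compound 1 `COc1ccc(C(N)=O)cc1/C=C/c1ccccc1F` gives 2000 nM and compound 2 `COc1ccc(C(N)=O)cc1/C=C/c1ccccc1C` gives 2300 nM. Methyl in place of fluoro gives a 1.2-fold higher number from compound 1 to compound 2 (0.06 log units; within the scatter), so these two compounds cannot be told apart. Compound 3 `COc1ccccc1/C=C/c1cc(C(N)=O)ccc1OC` has the highest number of the three at 5700 nM, which makes it the weakest inhibitor measured so far. Methoxy in place of fluoro gives a 2.9-fold higher number from compound 1 to compound 3 (0.45 log units; beyond the scatter), and methoxy in place of methyl gives a 2.5-fold higher number from compound 2 to compound 3 (0.39 log units; beyond the scatter). Both steps are modest.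

Compound 4 `COc1ccc(C(N)=O)cc1/C=C/c1ccccc1Cl` is not yet measured. It carries chloro in place of methoxy on an aromatic carbon, ortho to a large group: chloro in place of methoxy on an aromatic carbon. Within the data shown here, no chloro compound has been measured, so the only guides are the two steps into methoxy, read in reverse. On a 2.5-fold higher number from compound 2 to compound 3 (0.39 log units; beyond the scatter) and a 2.9-fold higher number from compound 1 to compound 3 (0.45 log units; beyond the scatter), a modest step to a lower number is expected in this assay, landing near compound 1 and compound 2 rather than staying with compound 3. The expected step is a 2.5-fold lower number from compound 3 to compound 4 (0.39 log units; beyond the scatter). The value for compound 4 is estimated at 2300 nM, with a range of 1200 nM to 4300 nM.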

Compound 4, half-maximal inhibitory concentration: 23000 nM
For compound 4 the middle estimate is 10-fold (1.00 log units) below the measured one, outside the stated range (above it).
By their numbers in this assay, from the lowest: compounds 1 and 2 (each within the scatter of the next); then compound 3; then compound 4.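

In this assay, among these compounds, this position proves less forgiving than the earlier compounds suggested: chloro in place of methoxy gives a 4.0-fold higher number from compound 3 to compound 4 (0.61 log units; beyond the scatter) in the same direction as the earlier steps into methoxy, which makes compound 4 the weakest inhibitor of the four. The two halogens also part company on an aromatic carbon ortho to a large group, since chloro in place of fluoro gives a 12-fold higher number from compound 1 to compound 4 (1.06 log units; beyond the scatter) and chloro in place of methyl gives a 10-fold higher number from compound 2 to compound 4 (1.00 log units; beyond the scatter), whereas fluoro and methyl could not be told apart. Chloro carries fewer heavy atoms than methoxy and no hydrogen-bond acceptor, yet compound 4 has the higher number, so for this one pair neither count follows the order of the numbers.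

No measured data bear on why chloro stands so far from fluoro, methyl and methoxy at this place. As far as these compounds go, it remains open whether the loss belongs to chloro alone or extends to bromo or trifluoromethyl, and how an amine or a carboxylic acid would read at the same position.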